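An Amide Substituent Exchanged at the Assay Limit

The source may report more compounds than this note shows. Statements on the series, on what has been measured and on what is new or still open speak of the compounds shown alone.

In a functional assay on BXPC-3 cells (Homo sapiens) for antiproliferative activity, read by MTT assay, with a stated time of 24 h (a lower number here means a stronger inhibitor, a higher number a weaker inhibitor), compound 2 (`CCn1c(C(=O)N[C@@H](CO)CCO)ccc1C(CC)(CC)c1ccc(OCS(=O)(=O)c2ccccc2)c(C)c1`) gives > 50000 nM, which is a limit and not a number. Compound 1 (`CCn1c(C(=O)N[C@@H](C)C(=O)OC)ccc1C(CC)(CC)c1ccc(OCS(=O)(=O)c2ccccc2)c(C)c1`) gives 17900 nM in this assay. Compound 3 (`CCn1c(C(=O)NCC(=O)O)ccc1C(CC)(CC)c1ccc(OCS(=O)(=O)c2ccccc2)c(C)c1`) has carboxymethyl in place of 3-hydroxy-1-(hydroxymethyl)propyl on the amide-type nitrogen: carboxymethyl in place of 3-hydroxy-1-(hydroxymethyl)propyl on an amide-type nitrogen. Going by the values given here, the one measured step at this nitrogen is an at least 2.7-fold higher number from compound 1 to compound 2 (0.44 log units; beyond the scatter), which lies beyond the scatter and ends at a limit. On that step alone, no change beyond the scatter is expected, and the estimated step is an at least 1.2-fold lower number from compound 2 to compound 3 (0.09 log units; that floor lies within the scatter). For compound 3 the estimate is 40000 nM, with an expected range of 18000 nM to 90000 nM.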

Compound 3, half-maximal inhibitory concentration: > 50000 nM
Compound 3: a limit, no number; the forecaster's own chance of this, stated with the estimate: 55%; at least 1.2-fold (0.09 log units) between middle value and limit.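

In this assay, compound 3, with carboxymethyl on the amide-type nitrogen, ends at a limit, > 50000 nM, and not at a number. A second replacement of the 1-(methoxycarbonyl)ethyl group of compound 1 therefore also gives a step beyond the scatter: an at least 2.7-fold higher number from compound 1 to compound 3 (0.44 log units; beyond the scatter). The step between compound 2 and compound 3 cannot be read because both stop at the limit: the limit of > 50000 nM in this assay, at which 2 of the 3 values shown sit.

As far as these compounds go, how far apart compound 2 and compound 3 truly lie remains open. So does whether an amine or a longer alkyl chain on this nitrogen would give a measurable number.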